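The source may hold more compounds than are shown below. What is called first, only, known or untested is meant among the compounds shown, and "the series" means these compounds.

Of the compounds shown here, three have been measured for inhibition of growth in a functional assay on KARPAS-422 cells (Homo sapiens) for inhibition, read by CCK-8 assay; a lower number here means a stronger inhibitor of growth, a higher number a weaker inhibitor of growth. Compound 1 `O=S(=O)(Nc1cc(-c2cnc3[nH]cc(-c4ccncc4)c3c2)cnc1Cl)c1ccccc1F` gives 350 nM, and compound 3 `O=S(=O)(Nc1cc(-c2cnc3[nH]cc(-c4ccncc4)c3c2)cnc1Cl)c1ccc(F)cc1` gives 370 nM; the step of a 1.1-fold higher number from compound 1 to compound 3 (0.02 log units; within the scatter) is within the scatter. Compound 2 `O=S(=O)(Nc1cc(-c2cnc3[nH]ncc3c2)cnc1Cl)c1ccccc1` gives 1090 nM, the highest number of the three, standing beyond the scatter from both compound 3 and compound 1.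

Compound 4 `O=S(=O)(Nc1cc(-c2cnc3[nH]nc(-c4ccncc4)c3c2)cnc1Cl)c1ccccc1` differs from compound 2 in one place: pyridin-4-yl in place of hydrogen on an aromatic carbon. Among the compounds with values here, no measured step covers this change on its own. Compound 1 and compound 3 both carry a pyridin-4-yl on their shared core and both give lower numbers than compound 2, but each also differs from compound 2 in the core ring and in the group on the sulfonyl sulfur, so their values only hint at the direction. On that hint a lower number is expected for compound 4, a step of about a 2.4-fold lower number from compound 2 to compound 4 (0.38 log units; beyond the scatter). The estimate for compound 4 in this assay is 450 nM, with a range from 150 nM to 1200 nM.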

Compound 4, concentration for 50% growth inhibition: 170 nM
Compound 4: middle estimate off by 2.6-fold (0.42 log units), on the high side; the range from low to high includes it.
By their numbers in this assay, from the lowest: compound 4; then compounds 1 and 3 (each within the scatter of the next); then compound 2.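

In this assay the step of a 6.4-fold lower number from compound 2 to compound 4 (0.81 log units; beyond the scatter) comes from one change alone: pyridin-4-yl in place of hydrogen on an aromatic carbon of the five-membered aromatic ring with 2 nitrogen. Compound 1 and compound 3 differ from compound 2 in more than one place and could only hint at this, whereas this pair ties a change beyond the scatter directly to this carbon. Nothing measured here explains the size or direction of the step.

Still open, as far as these compounds go, is whether the ring nitrogen of the pyridin-4-yl matters: a phenyl ring, a methyl or an amine on the same carbon would test that. From the compounds shown here alone, it is also open whether the step holds with a 2-fluorophenyl or 4-fluorophenyl on the sulfonyl sulfur.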